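The source may report more compounds than this note shows. Statements on the series, on what has been measured and on what is new or still open speak of the compounds shown alone.

Compound 1 `O=C(Nc1ccc(-n2ncc3c(Br)cccc32)cc1)Nc1ccc(Cl)c(C(F)(F)F)c1` gives 1700 nM in a functional assay on LoVo cells (Homo sapiens) for cytotoxicity, read by MTT assay, with a stated time of 72 h; a lower number here means a stronger inhibitor, a higher number a weaker inhibitor. Compound 2 `O=C(Nc1ccc(-n2ncc3cnccc32)cc1)Nc1ccc(Cl)c(C(F)(F)F)c1` gives 8000 nM in this assay, and compound 3 `O=C(Nc1ccc(-n2ncc3ccncc32)cc1)Nc1ccc(Cl)c(C(F)(F)F)c1` gives 7100 nM in this assay, the second highest number among the three; the step of a 4.2-fold higher number from compound 1 to compound 3 (0.62 log units; beyond the scatter) lies beyond the scatter, whereas a 1.1-fold lower number from compound 2 to compound 3 (0.05 log units; within the scatter) stays within it. Compound 4 `O=C(Nc1ccc(-n2ncc3cccnc32)cc1)Nc1ccc(Cl)c(C(F)(F)F)c1` differs from compound 3 by a group of 9 heavy atoms (6 carbon, 3 nitrogen; one five-membered aromatic ring with 2 hetero atoms, one six-membered aromatic ring with 1 hetero atom) in place of a group of 9 heavy atoms (6 carbon, 3 nitrogen; one five-membered aromatic ring with 2 hetero atoms, one six-membered aromatic ring with 1 hetero atom), on an aromatic carbon, the same atoms joined differently. Among the compounds with values here, the only measured step of this same kind, a 1.1-fold lower number from compound 2 to compound 3 (0.05 log units; within the scatter), produced no change beyond the scatter, so no step beyond the scatter in this assay is expected here either. Compound 4 is therefore expected to give 7000 nM in this assay, with a likely range from 3000 nM to 16000 nM. That expectation amounts to the step of a 1.0-fold lower number from compound 3 to compound 4 (0.01 log units; within the scatter).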

Compound 4, half-maximal inhibitory concentration: 32000 nM
For compound 4 the middle estimate is 4.6-fold (0.66 log units) below the measured one; the measured number lies above the stated range.
By their numbers in this assay, from the lowest: compound 1; then compounds 3 and 2 (each within the scatter of the next); then compound 4.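

In this assay, the same atoms joined differently are not always interchangeable at this position: a 4.5-fold higher number from compound 3 to compound 4 (0.65 log units; beyond the scatter) and a 4.0-fold higher number from compound 2 to compound 4 (0.60 log units; beyond the scatter) both lie beyond the scatter, unlike the earlier 1.1-fold lower number from compound 2 to compound 3 (0.05 log units; within the scatter). The rearrangement in compound 4 also widens the gap to the bromine-bearing compound, with a 19-fold higher number from compound 1 to compound 4 (1.27 log units; beyond the scatter). Nothing available accounts for this difference among the rearranged groups.

The compounds shown leave open whether a chlorine atom or an amine in place of the bromine of compound 1 would give a lower or a higher number.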